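The source may hold more compounds than are shown below. What is called first, only, known or untested is meant among the compounds shown, and "the series" means these compounds.

Values in a functional assay on PC-3 cells (Homo sapiens) for inhibition, read by sulforhodamine B assay; on this read-out higher numbers stand for weaker inhibition of growth and lower numbers for stronger inhibition of growth:
- compound 1 `FC(F)(F)Oc1ccc(-c2ccc(-c3ccc(-c4nc5ccccc5[nH]4)cc3)cc2)cc1`: 100000 nM
- compound 2 `Oc1cccc2[nH]c(-c3ccc(-c4ccc(-c5ccc(OC(F)(F)F)cc5)cc4)cc3)nc12`: 7410 nM
- compound 3 `Cc1ccc2[nH]c(-c3ccc(-c4ccc(-c5ccccc5)cc4)cc3)nc2c1`: 100000 nM

Compound 3 stands level with compound 1, and together they hold the highest number of the three. Compound 2 holds the lowest number of the three, 7410 nM.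

The next compound is compound 4 `Cc1ccc2[nH]c(-c3ccc(-c4ccc(-c5ccc(OC(F)(F)F)cc5)cc4)cc3)nc2c1`, which has trifluoromethoxy in place of hydrogen on an aromatic carbon.

Within the data shown here, the only measured step, a 13-fold lower number from compound 1 to compound 2 (1.13 log units; beyond the scatter), is large but is a hydroxy change, so it gives no direct size for this one. Among the measured compounds shown here, no measured step isolates trifluoromethoxy. The nearest evidence is compound 1, which carries that group without the methyl and still gives 100000 nM, level with compound 3. No step beyond the scatter is therefore expected in this assay, though a slightly lower number is possible. The expected step is small: a 1.4-fold lower number from compound 3 to compound 4 (0.15 log units; within the scatter). For compound 4 the estimated value is 70000 nM, with an expected range of 15000 nM to 100000 nM.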

Compound 4, concentration for 50% growth inhibition: 2010 nM
The estimate for compound 4 lay 35-fold (1.54 log units) above the measured number, outside the stated range (below it).
By their numbers in this assay, from the lowest: compound 4; then compound 2; then compounds 1 and 3 (each within the scatter of the next).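

In this assay, among these compounds, the phenyl to 4-(trifluoromethoxy)phenyl change gives a 50-fold lower number from compound 3 to compound 4 (1.70 log units; beyond the scatter) and methyl in place of hydrogen gives a 50-fold lower number from compound 1 to compound 4 (1.70 log units; beyond the scatter) yet with only one of the two groups present compound 1 stays at 100000 nM and compound 3 at 100000 nM in the same assay, so here each change shows its step only with the other group present. With trifluoromethoxy kept, the swap of 4-hydroxy-1H-benzimidazol-2-yl for 5-methyl-1H-benzimidazol-2-yl gives a 3.7-fold lower number from compound 2 to compound 4 (0.57 log units; beyond the scatter) and this modest step leaves the methyl ahead of the hydroxy group. No measurement at hand explains why the two changes depend on each other.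

From the compounds shown here alone, whether a methoxy group or an amine could stand in place of the methyl remains open. Also open, going by these compounds, is whether a longer chain or a carboxylic acid could replace trifluoromethoxy and keep this level of growth inhibition.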